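Alkenyl ether to benzyl ether on a pyridine core

The source may hold more compounds than are shown below. What is called first, only, known or untested is meant among the compounds shown, and "the series" means these compounds.

Measured compounds:
compound 1, `CCCCCOc1cc(CCc2nc(C)c(CC)s2)nc(NCc2cc(Cl)cc(NC(=O)OC(C)C)c2)c1`: 35 nM
compound 2, `CC/C=C\CCOc1cc(CCc2nc(C)c(CC)s2)nc(NCc2cc(Cl)cc(NC(=O)OC(C)C)c2)c1`: 4.7 nM

In an assay on cells for binding affinity to Neuropeptide Y receptor type 1 (Homo sapiens) (on this read-out lower numbers stand for stronger inhibition and higher numbers for weaker inhibition), compound 2 gives the lowest of the two numbers; compound 1 sits a 7.4-fold lower number from compound 1 to compound 2 (0.87 log units; beyond the scatter) away. Compound 3, `CCc1sc(CCc2cc(OCc3ccccc3)cc(NCc3cc(Cl)cc(NC(=O)OC(C)C)c3)n2)nc1C`, has not been measured. The change is phenyl in place of pent-2-en-1-yl on a saturated chain carbon bound to an oxygen on an aromatic ring. Going by the values given here, the only measured step alters the same chain farther out, and it was a 7.4-fold lower number from compound 1 to compound 2 (0.87 log units; beyond the scatter). Among the compounds with values here, no step exchanges a chain for a ring, so the account rests on that one step. Compound 3 is expected to give 15 nM, within 3 nM to 70 nM, a step of a 3.2-fold higher number from compound 2 to compound 3 (0.50 log units; beyond the scatter) expected from compound 2.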

Compound 3, half-maximal inhibitory concentration: 237 nM
The estimate for compound 3 lay 16-fold (1.20 log units) below the measured number; measured number outside the range, above it.
By their numbers in this assay, from the lowest: compound 2; then compound 1; then compound 3.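

In this assay, phenyl on the saturated chain carbon bound to an oxygen on an aromatic ring is poorly matched by either chain: a 50-fold higher number from compound 2 to compound 3 (1.70 log units; beyond the scatter), and a 6.8-fold higher number from compound 1 to compound 3 (0.83 log units; beyond the scatter). Among these compounds, both open chains give lower numbers than the ring, so the gain seen with the alkenyl chain does not extend to this phenyl. Nothing on hand explains the loss. The compounds leave open whether the aromatic ring itself or any ring costs affinity here. Cyclohexyl or 2-phenylethyl in this place would separate those readings.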